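The source may report more compounds than this note shows. Statements on the series, on what has been measured and on what is new or still open speak of the compounds shown alone.

Compound 1 `CCC(c1ccccc1)c1nc(-c2ccc(Cl)cc2)c(CC(=O)O)s1` gives > 100000 nM in an in vitro functional assay on HEK285-7 cells for antagonist activity at prostaglandin D2 receptor 2 (Homo sapiens), read by BRET and beta-arrestin recruitment; on this read-out lower numbers stand for stronger inhibition and higher numbers for weaker inhibition; this is a limit of the assay, not a number.
Compound 2 `O=C(O)Cc1sc(C(c2ccccc2)c2ccccc2)nc1-c1ccc(C(F)(F)F)cc1` gives > 100000 nM in this assay, again a limit and not a number.
Compound 3 `O=C(O)Cc1sc(C2COc3ccccc3O2)nc1-c1ccc(Cl)cc1` gives 2000 nM in this assay.

All three share the same core carrying the carboxylic acid chain and differ only in the group on the saturated chain carbon. For the measured compounds named here, compound 1 stands at the limit of > 100000 nM in this assay, at which 2 of the 3 values shown sit, so its true number is unknown and it has no measured step to any other compound. Compound 4 `O=C(O)Cc1sc(C(c2ccccc2)c2ccc(F)cc2)nc1-c1ccc(Cl)cc1` is compound 1 with 4-fluorophenyl in place of ethyl on a saturated chain carbon bound to two aromatic carbons. Compound 2, which also carries two aromatic rings on that chain carbon, likewise sits at the limit, while compound 3 carries a different group there and gives a number. Going by the values given here, no measured pair shows this exact change, so the expectation rests on these three values alone. The step of an at least 1.6-fold lower number from compound 1 to compound 4 (0.22 log units; that floor lies within the scatter) is expected to be modest, toward somewhat stronger inhibition, but with much uncertainty because compound 1 itself is only > 100000 nM. Compound 4 is estimated at 60000 nM, between 8000 nM and 200000 nM, with a real chance that only a limit is reported again.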

Compound 4, half-maximal inhibitory concentration: 36 nM
Compound 4: middle estimate off by 1700-fold (3.22 log units), on the high side; the whole stated range lies above it.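

In this assay, for the compounds shown here, putting 4-fluorophenyl in place of ethyl on a saturated chain carbon bound to two aromatic carbons gives an at least 2700-fold lower number from compound 1 to compound 4 (3.44 log units; beyond the scatter), so what this position carries can matter a great deal, which no earlier compound could show on its own. That step is only a floor and its true size is unknown, since the value for compound 1 is a limit and not a number: the limit of > 100000 nM in this assay, at which 2 of the 4 values shown sit.

Compound 2 also carries two aromatic rings on this chain carbon, but it differs from compound 4 in more than one place, so its limit cannot show what this single change does.

The compounds shown leave open whether the gain needs the fluorine or whether a second aromatic ring is enough; a plain phenyl at this place, with the rest of compound 4 kept, would separate the two. They also leave open how a cyclohexyl ring or a pyridine ring would behave on the same carbon, and so whether the new group must be an aromatic ring of carbon only.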